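Lengthening the hydroxy chain of compound 3

A few compounds are considered here, and "the series" means these few. Any claim that something is new, unique, unknown or untested is made for them only; others in the source may bear on it.

In a functional assay (Pituitary gland cell) with Rattus norvegicus as the target (a higher number here means that more compound is needed for the effect, a lower number that less compound is needed), the measured compounds stand thus
Compound 1 `CCNC(=O)c1ccccc1-c1ccc(CN2C(=O)[C@H](NC(=O)CC(C)(C)N)CCc3ccccc32)cc1` gives 0.09 uM here
Compound 2 `CCN(CC)C(=O)c1ccccc1-c1ccc(CN2C(=O)[C@H](NC(=O)CC(C)(C)N)CCc3ccccc32)cc1` gives 2 uM here
Compound 3 `CC(C)(N)CC(=O)N[C@@H]1CCc2ccccc2N(Cc2ccc(-c3ccccc3C(=O)NCCO)cc2)C1=O` gives 3 uM here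

Compound 3 lies at the high end of these numbers, with a 33-fold higher number from compound 1 to compound 3 (1.52 log units; beyond the scatter) and a 1.5-fold higher number from compound 2 to compound 3 (0.18 log units; within the scatter) on record. Compound 4 `CC(C)(N)CC(=O)N[C@@H]1CCc2ccccc2N(Cc2ccc(-c3ccccc3C(=O)NCCCCO)cc2)C1=O` differs from it by 2-hydroxyethyl in place of hydroxy on a saturated chain carbon, two bonds along the chain from an amide-type nitrogen on a saturated chain carbon, two bonds along the chain from an amide-type nitrogen, turning (2-hydroxyethyl)amino into (4-hydroxybutyl)amino. Among the compounds with values here, no measured step lengthens such a chain. The nearest evidence is the large hydroxy step from the chain of compound 1, which gives 0.09 uM without any hydroxy, so only a modest fall in the number is expected, and its direction is uncertain. The expected step is a 3.0-fold lower number from compound 3 to compound 4 (0.48 log units; beyond the scatter) at this stage. Compound 4 is estimated to give 1 uM within a range of 0.2 uM to 5 uM in this assay once measured.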

Compound 4, concentration for half-maximal effect: 0.01 uM
The estimate for compound 4 lay 100-fold (2.00 log units) above the measured number; the whole stated range lies above it.
By their numbers in this assay, from the lowest: compound 4; then compound 1; then compounds 2 and 3 (each within the scatter of the next).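

In this assay, a hydroxy-bearing chain on this amide nitrogen proves no fixed penalty: 2-hydroxyethyl in place of hydroxy at this saturated chain carbon gives a 300-fold lower number from compound 3 to compound 4 (2.48 log units; beyond the scatter) and turns the (2-hydroxyethyl)amino result around. The (4-hydroxybutyl)amino group also outdoes diethylamino, with a 200-fold lower number from compound 2 to compound 4 (2.30 log units; beyond the scatter) on record, and the chain of compound 4 surpasses the plain ethyl amide, with a 9.0-fold lower number from compound 1 to compound 4 (0.95 log units; beyond the scatter) on record. Nothing at hand accounts for this change. On these data alone, whether a longer chain lowers the number further remains open. So does whether the terminal hydroxy is needed, or could give way to an amine or a carboxylic acid.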